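Methyl for methoxy on the shared core: expected step

This account rests on a few compounds, and the source may have more. Where it says the series, first, only, none or still open, it means among the compounds named here.

Three analogues have been measured in a functional assay on the whole organism for inhibition, with Brassica napus as the target, with a stated time of 72 h, tested at 100 mg/L; on this read-out higher numbers stand for more inhibition of growth at the one concentration tested and lower numbers for less inhibition of growth. Compound 1 `COc1cc(Cl)nc(NC(=S)NC(=O)c2c(-c3ccc(Cl)cc3Cl)noc2C)n1` gives 61%, compound 2 `Cc1cc(Cl)nc(NC(=S)NC(=O)c2c(-c3ccc(Cl)cc3Cl)noc2C)n1` gives 50.8%, and compound 3 `COc1cc(OC)nc(NC(=S)NC(=O)c2c(-c3ccc(Cl)cc3Cl)noc2C)n1` gives 70.8%. Compound 4 `COc1cc(C)nc(NC(=S)NC(=O)c2c(-c3ccc(Cl)cc3Cl)noc2C)n1` has not been measured.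

The change from compound 1 to compound 2, (methyl in place of methoxy on an aromatic carbon), made the step of a number 10.2 percentage points lower from compound 1 to compound 2 (beyond the scatter). The same kind of change is made from compound 3 to compound 4, (methyl in place of methoxy on an aromatic carbon). The surroundings are not identical: in compound 1 the place is meta to a chloro group (1 heavy atom), whereas in compound 3 it is meta to a methoxy group (2 heavy atoms). The cores of compound 1 and compound 3 differ by methoxy in place of chloro on an aromatic carbon, which gave a number 9.8 percentage points higher from compound 1 to compound 3 (within the scatter). Between compound 2 and compound 3 the step is a number 20 percentage points higher from compound 2 to compound 3 (beyond the scatter).

Among the compounds with values here, for compound 4 a step of a number 9.8 percentage points lower from compound 3 to compound 4 (within the scatter) is expected in this assay, resting on the single earlier case a number 10.2 percentage points lower from compound 1 to compound 2 (beyond the scatter). Compound 4 is accordingly estimated at 61%, with a plausible span from 50% to 71%.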

Compound 4, percent growth inhibition at one concentration: 69.3%
Compound 4: the middle estimate sits 8.3 percentage points below what was measured; the measured number falls inside the stated range.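

In this assay, methyl in place of methoxy gives a number 1.5 percentage points lower from compound 3 to compound 4 (within the scatter), and this step carries over from the earlier core within the scatter: the same change on two cores in this assay, a number 10.2 percentage points lower (beyond the scatter) from compound 1 to compound 2 and a number 1.5 percentage points lower (within the scatter) from compound 3 to compound 4, 8.7 percentage points apart, within the scatter of two such steps. Methoxy in place of chloro, seen here as a number 18.5 percentage points higher from compound 2 to compound 4 (beyond the scatter), also carries over between cores within the scatter: the same change on two cores in this assay, a number 9.8 percentage points higher (within the scatter) from compound 1 to compound 3 and a number 18.5 percentage points higher (beyond the scatter) from compound 2 to compound 4, 8.7 percentage points apart, within the scatter of two such steps. This supports carrying either change within these four compounds, but it fixes no size for either one: each rests on only two cases, with one step within the scatter and the other beyond it, and methyl in place of chloro, a number 8.3 percentage points higher from compound 1 to compound 4 (within the scatter), has no second case here.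

Only chloro, methyl and methoxy appear at the two varied places, leaving open what an amine, an ethoxy group or a trifluoromethyl group would do there. The rest of the shared core stays the same throughout, and every value comes from a single concentration, leaving open whether these steps hold on other cores or at other concentrations.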